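The compounds below may be only part of what the source reports. "The series", "measured", "known", "first", "only" and "open" are said of these compounds alone.

Measured compounds in an assay on HEK293 cells for displacement of a labelled ligand from 5-hydroxytryptamine receptor 7 (Rattus norvegicus); a higher number here means a weaker inhibitor, a lower number a stronger inhibitor:
- compound 1 `CSc1ccccc1N1CCN(CCCCCC(=O)N2CCc3ccccc3C2)CC1`: 32.9 nM
- compound 2 `CC(C)c1ccccc1N1CCN(CCCCCC(=O)N2CCc3ccccc3C2)CC1`: 6 nM
- compound 3 `CC(C)c1ccccc1N1CCN(CCCCCC(=O)NCc2ccncc2)CC1`: 5.1 nM

All three share the arylpiperazine linked through a six-carbon chain to an amide carbonyl; they differ in the aromatic substituent on the piperazine-bearing ring and in the group on the carbonyl carbon. Compound 3 shows the lowest number of the three, but its separation from compound 2 is within the scatter, as the step of a 1.2-fold lower number from compound 2 to compound 3 (0.07 log units; within the scatter) makes plain, whereas the step of a 5.5-fold lower number from compound 1 to compound 2 (0.74 log units; beyond the scatter) is beyond it. For the measured compounds named here, the only step that is clearly resolved is therefore the one on the aromatic substituent, not the one on the amide side.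

Compound 4 `CC(C)c1ccccc1N1CCN(CCCCCC(=O)NCc2ccc(C#N)cc2)CC1` is the next member. It differs from compound 3 in one place: 4-cyanophenyl in place of pyridin-4-yl on a saturated chain carbon bound to an amide-type nitrogen. Going by the values given here, no measured step exchanges one aryl group for another at this position. Among the compounds with values here, the one step that bears on the amide side, a 1.2-fold lower number from compound 2 to compound 3 (0.07 log units; within the scatter), changed the group on the carbonyl carbon far more drastically and still stayed within the scatter, which speaks for a tolerant position. The estimated step of a 1.3-fold higher number from compound 3 to compound 4 (0.11 log units; within the scatter) is accordingly expected to be none beyond the scatter. For compound 4 the expected value in this assay is 6.5 nM, estimated to lie between 2.5 nM and 18 nM.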

Compound 4, inhibition constant: 8.6 nM
For compound 4 the middle estimate is 1.3-fold (0.12 log units) below the measured one, and the stated range covers the measured number.
By their numbers in this assay, from the lowest: compounds 3, 2 and 4 (each within the scatter of the next); then compound 1.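

For the compounds shown here, this is the first exchange of one aromatic ring for another on the saturated chain carbon bound to an amide-type nitrogen. In this assay the change from pyridin-4-yl to 4-cyanophenyl gives a 1.7-fold higher number from compound 3 to compound 4 (0.23 log units; within the scatter) and so does not resolve a ring of carbon only carrying a nitrile from a ring with one hetero atom. The comparison with the tetrahydroisoquinoline amide gives the same reading for a second replacement on the carbonyl carbon, with (4-cyanobenzyl)amino in place of 1,2,3,4-tetrahydroisoquinolin-2-yl giving a 1.4-fold higher number from compound 2 to compound 4 (0.16 log units; within the scatter), so all three amide-side groups on the isopropyl series remain unresolved from one another, and no measurement available here explains this tolerance.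

Still open is whether the position stays this tolerant with a carboxylic acid or an aminomethyl group in place of the nitrile on the benzyl ring, as all the groups shown on this side are neutral aromatic or fused-ring amides. As far as these compounds go, it is also open whether the (4-cyanobenzyl)amino group behaves the same way with methylsulfanyl in place of isopropyl on the aromatic ring, or with a shorter chain leading to the carbonyl.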